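The source may report more compounds than this note shows. Statements on the series, on what has been measured and on what is new or still open speak of the compounds shown alone.

The measured compounds, in a functional assay on HepG2 cells (Homo sapiens) for antiproliferative activity, read by MTT assay, with a stated time of 72 h; a lower number here means a stronger inhibitor, a higher number a weaker inhibitor:

- compound 1 `O=C1O[C@H]([C@@H](O)Cn2cc(-c3ccc(Br)cc3)nn2)C(OCc2ccccc2)=C1OCc1ccccc1` gives 5070 nM
- compound 2 `O=C1O[C@H]([C@@H](O)Cn2cc(-c3cccc(O)c3)nn2)C(OCc2ccccc2)=C1OCc1ccccc1` gives 62700 nM
- compound 3 `O=C1O[C@H]([C@@H](O)Cn2cc(CNS(=O)(=O)c3ccc(Cl)cc3)nn2)C(OCc2ccccc2)=C1OCc1ccccc1` gives 7510 nM

Compound 3 stands second highest of these three numbers. Its nearest neighbour is compound 1: a 1.5-fold higher number from compound 1 to compound 3 (0.17 log units; within the scatter). Its furthest is compound 2: an 8.3-fold lower number from compound 2 to compound 3 (0.92 log units; beyond the scatter). Compound 4 `Cc1ccc(S(=O)(=O)NCc2cn(C[C@H](O)[C@H]3OC(=O)C(OCc4ccccc4)=C3OCc3ccccc3)nn2)cc1` differs from compound 3 in one place: methyl in place of chloro on an aromatic carbon. Among the measured compounds shown here, none of the measured steps bears on this change; the two that touch this part of the molecule, a 1.5-fold higher number from compound 1 to compound 3 (0.17 log units; within the scatter) and an 8.3-fold lower number from compound 2 to compound 3 (0.92 log units; beyond the scatter), swap the whole side group rather than a single substituent on the ring that carries the sulfonyl. With nothing pointing either way, compound 4 is expected to sit close to compound 3, with a 1.1-fold higher number from compound 3 to compound 4 (0.03 log units; within the scatter) not beyond the scatter. The estimate for compound 4 in this assay is 8000 nM, within a range of 3000 nM to 25000 nM.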

Compound 4, half-maximal inhibitory concentration: 24900 nM
The estimate for compound 4 lay 3.1-fold (0.49 log units) below the measured number, and the stated range covers the measured number.
By their numbers in this assay, from the lowest: compounds 1 and 3 (each within the scatter of the next); then compound 4; then compound 2.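

In this assay, among the compounds shown here, the single exchange of chloro for methyl on the ring that carries the sulfonyl (a 3.3-fold higher number from compound 3 to compound 4 (0.52 log units; beyond the scatter)) shows that this one substituent alone moves the number beyond the scatter, which the whole-group swaps could not show. With methyl in place, the side group no longer stays within the scatter of the 4-bromophenyl group (a 4.9-fold higher number from compound 1 to compound 4 (0.69 log units; beyond the scatter)), though it keeps a lower number than the 3-hydroxyphenyl group (a 2.5-fold lower number from compound 2 to compound 4 (0.40 log units; beyond the scatter)). No measurement at hand explains the difference. The compounds shown leave open how fluoro, methoxy or an amine on this same aromatic carbon would compare with chloro and methyl.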